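Three measured imines and one desmethyl analogue still to test

The source may hold more compounds than are shown below. What is called first, only, known or untested is meant among the compounds shown, and "the series" means these compounds.

Measured so far, in a functional assay, read by spectrophotometry, with a stated time of 30 min; on this read-out higher numbers stand for weaker inhibition and lower numbers for stronger inhibition:
compound 1, `Cc1ccc2[nH]c(=O)c(/C=N/c3ccccc3O)cc2c1`, gives 26200 nM;
compound 2, `Cc1ccc2[nH]c(=O)c(/C=N/Nc3ccccc3)cc2c1`, gives 62400 nM;
compound 3, `O=c1[nH]c2ccccc2cc1/C=N/Nc1ccccc1`, gives 76500 nM.

Compound 1 has the lowest number of the three. Its nearest neighbour is compound 2, reached by 2-hydroxyphenyl in place of anilino on a double-bonded nitrogen; that change made a 2.4-fold higher number from compound 1 to compound 2 (0.38 log units; beyond the scatter), a modest step. Compound 2 and compound 3 differ by hydrogen in place of methyl on an aromatic carbon, and there the step was a 1.2-fold higher number from compound 2 to compound 3 (0.09 log units; within the scatter), a step that stays within the scatter of this assay.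

Compound 4, `O=c1[nH]c2ccccc2cc1/C=N/c1ccccc1O`, is not yet measured. It stands to compound 1 as compound 3 stands to compound 2: the difference is hydrogen in place of methyl on an aromatic carbon. The two place descriptions match word for word, so this is the same change made on a core that differs only as just described. The expectation for compound 4 therefore rests on the step from compound 2 to compound 3, a 1.2-fold higher number from compound 2 to compound 3 (0.09 log units; within the scatter), which was small, and compound 4 is expected to show a 1.2-fold higher number from compound 1 to compound 4 (0.07 log units; within the scatter). Compound 4 is estimated at 31000 nM, with the range 15000 nM to 65000 nM.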

Compound 4, half-maximal inhibitory concentration: 22800 nM
Estimate against measurement, compound 4: 1.4-fold (0.13 log units) above, and the stated range covers the measured number.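

In this assay, hydrogen in place of methyl on an aromatic carbon gave a 1.1-fold lower number from compound 1 to compound 4 (0.06 log units; within the scatter), so on the core of compound 1 this change made no difference that can be told from the scatter. The same change on the two cores, one carrying 2-hydroxyphenyl and the other anilino on the double-bonded nitrogen, gave steps that do not differ beyond the scatter: the same change on two cores in this assay, a 1.2-fold higher number (0.09 log units; within the scatter) from compound 2 to compound 3 and a 1.1-fold lower number (0.06 log units; within the scatter) from compound 1 to compound 4, 1.4-fold (0.15 log units) apart, within the scatter of two such steps. This shows that the change carried over between these two closely related cores as a small step, but both steps are too small for their opposite directions to mean anything, and two cases do not show that it would stay small on other cores or in another assay.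

Going by these compounds, only methyl and hydrogen appear at this aromatic carbon, so it remains open whether an ethyl group, a methoxy group or a chlorine atom there would move the number beyond the scatter. On these data alone, it also remains open whether an amine or a carboxylic acid in place of the hydroxyl of the 2-hydroxyphenyl group would do so.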